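The source may report more compounds than this note shows. Statements on the series, on what has been measured and on what is new or still open speak of the compounds shown alone.

Measured compounds in a functional assay on cells (Rhabdomyosarcoma cell, Homo sapiens) for cytotoxicity; a lower number here means a stronger inhibitor, a higher number a weaker inhibitor:

Compound 1, `c1ccc(C(c2ccccn2)N2CCN(c3ncnc4c3cnn4-c3ccccc3)CC2)cc1`, gives > 25000 nM in this assay, a limit rather than a number.
Compound 2, `c1ccc(C(c2ccncc2)N2CCN(c3ncnc4c3cnn4-c3ccccc3)CC2)cc1`, gives > 25000 nM in this assay, again only a limit.
Compound 3, `N#Cc1ccc(C(c2ccccc2)N2CCN(c3ncnc4c3cnn4-c3ccccc3)CC2)cc1`, gives > 25000 nM in this assay, also a limit.

Compound 3 therefore stands at the same limit as the other two values shown; all three sit there (the limit of > 25000 nM in this assay, at which 3 of the 3 values shown sit). The steps between the measured compounds cannot be read: a step that the two limits leave unreadable from compound 1 to compound 2, a step that the two limits leave unreadable from compound 1 to compound 3 and a step that the two limits leave unreadable from compound 2 to compound 3. None of them gives a readable size, so none can be used to scale the next change.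

The step to compound 4, `c1ccc(C(c2ccccc2)N2CCN(c3ncnc4c3cnn4-c3ccccc3)CC2)cc1`, is hydrogen in place of cyano on an aromatic carbon. Within the data shown here, no measured step bears on this change with a readable size, so no direction is indicated for this assay, and the only guide is that every value so far is a limit. Compound 4 is therefore expected to remain at or near the limit, with an estimated step that the limit leaves unreadable from compound 3 to compound 4. The estimate for compound 4 in this assay is 40000 nM, with a range from 15000 nM to 120000 nM, and a reported limit rather than a number is the likely outcome.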

Compound 4, half-maximal inhibitory concentration: > 25000 nM
Compound 4 ended at the assay's limit; the forecaster's own chance of this, stated with the estimate: 85%; the middle value lies beyond the limit too.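

None of the steps from compound 1, compound 2 or compound 3 to compound 4 can be read in this assay, and the series rests on a single limit: the limit of > 25000 nM in this assay, at which 4 of the 4 values shown sit.

The compounds shown leave open how far each lies past that limit, and whether any of these group changes alters the read-out at all.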